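This account rests on a few compounds, and the source may have more. Where it says the series, first, only, none or still open, it means among the compounds named here.

Measured compounds: compound 1 `COc1cc(C(=O)O)ccc1OCCCCOc1ccc(C(=O)CC(C)C)c(O)c1C` at 43%; compound 2 `CCC(=O)c1ccc(OCCCCOc2ccc(F)c(C(=O)O)c2)c(C)c1O` at 35%; compound 3 `Cc1c(OCCCCOc2ccc(F)c(C(=O)O)c2)ccc(C(=O)C(C)C)c1O` at 60%.

All three were tested in an ADME assay (liver) for metabolic stability, with Liver microsome (Rattus norvegicus) as the target, read by LC-MS, using microsomes and NADPH, with stated times of 5 min and 60 min, tested at 4 uM; a lower number here means that less of the compound is left, a higher number that more of the compound is left. Compound 1 and compound 2 are within the scatter of each other; the difference between their two cores is not broken down here. Compound 3 carries methyl in place of hydrogen on a saturated chain carbon bound to a carbonyl carbon and a saturated chain carbon, and a number 25 percentage points higher from compound 2 to compound 3 (beyond the scatter).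

Compound 4 `COc1cc(C(=O)O)ccc1OCCCCOc1ccc(C(=O)CC(C)(C)C)c(O)c1C`, not yet measured, carries methyl in place of hydrogen on a saturated chain carbon bound to three saturated chain carbons. This is the same kind of change as that from compound 2 to compound 3, but not the same: there the place was a saturated chain carbon bound to a carbonyl carbon and a saturated chain carbon, here it is a saturated chain carbon bound to three saturated chain carbons. Resting on a number 25 percentage points higher from compound 2 to compound 3 (beyond the scatter), compound 4 is expected to move as a number 9 percentage points higher from compound 1 to compound 4 (within the scatter), a smaller step. Compound 4 is thus estimated at 52%, between 35% and 68%.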

Compound 4, percent of the compound remaining: 49%
For compound 4 the middle estimate is 3 percentage points above the measured one; the measured number falls inside the stated range.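

In this assay, the change from isobutylcarbonyl to neopentylcarbonyl on the core of compound 1 comes with a number 6 percentage points higher from compound 1 to compound 4 (within the scatter). A methyl in place of hydrogen on a saturated chain carbon therefore did not carry over at the same size from one core to the other: the same change on two cores in this assay, a number 25 percentage points higher (beyond the scatter) from compound 2 to compound 3 and a number 6 percentage points higher (within the scatter) from compound 1 to compound 4, 19 percentage points apart, beyond the scatter of two such steps With a single pair on each core, and the methyl on a differently bound carbon in each pair, this does not show whether the core or the place of the methyl sets the gap, and it gives no rule for other cores. The compounds shown leave open how a longer chain or a cyclopropyl group in place of the neopentyl group would read in this assay.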